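A Hydroxynaphthyl Group Replaces the Styryl Group of Compound 3

The source may report more compounds than this note shows. Statements on the series, on what has been measured and on what is new or still open speak of the compounds shown alone.

Compound 3 `N#CC1=C(N)N(c2ccc(S(N)(=O)=O)cc2)C2=C(CCCC2)C1/C=C/c1ccccc1` stands lowest of the three compounds measured in a functional assay on Ehrlich cells (Mus musculus) for cytotoxicity, read by trypan blue exclusion, with a stated time of 2 h, tested at 100 ug/mL; a higher number here means a stronger effect of the compound at the concentration tested, a lower number a weaker effect: compound 3 gives 70%, while compound 1 `Cc1ccc(C2C(C#N)=C(N)N(c3ccc(S(N)(=O)=O)cc3)C3=C2CCCC3)cc1` gives 90% and compound 2 `N#CC1=C(N)N(c2ccc(S(N)(=O)=O)cc2)C2=C(CCCC2)C1c1ccc(O)cc1` gives 100%. Compound 4 `N#CC1=C(N)N(c2ccc(S(N)(=O)=O)cc2)C2=C(CCCC2)C1c1c(O)ccc2ccccc12` differs from compound 3 in one place: 2-hydroxynaphthalen-1-yl in place of 2-phenylethenyl on a saturated ring carbon. Within the data shown here, two measured steps bear on this change, a number 30 percentage points lower from compound 2 to compound 3 (beyond the scatter) and a number 20 percentage points lower from compound 1 to compound 3 (beyond the scatter); each put 2-phenylethenyl on that saturated ring carbon in place of an aryl group and each lowered the number beyond the scatter. Returning to an aryl group there, now carrying a hydroxy, is therefore expected to raise the number in this assay: a number 15 percentage points higher from compound 3 to compound 4 (beyond the scatter). Compound 4 is accordingly estimated to give 85%, within the range 60% to 100%.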

Compound 4, a percentage reported as activity, at one concentration (the size of the read-out at that concentration, not a potency): 50%
The estimate for compound 4 lay 35 percentage points above the measured number, and the stated range ends above it.
By their numbers in this assay, from the lowest: compound 4; then compound 3; then compounds 1 and 2 (each within the scatter of the next).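

In this assay, an aryl group on this saturated ring carbon does not by itself keep the number high: the change to 2-hydroxynaphthalen-1-yl gives a number 20 percentage points lower from compound 3 to compound 4 (beyond the scatter). A hydroxy on the aryl group does not keep it high either, as the steps show: a number 50 percentage points lower from compound 2 to compound 4 (beyond the scatter), and a number 40 percentage points lower from compound 1 to compound 4 (beyond the scatter). No evidence on the cause of this fall is at hand.

Going by these compounds, whether the second aromatic ring or the place of the hydroxy matters remains open. A 2-hydroxyphenyl or a plain naphthalen-1-yl group on this carbon would separate the two.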